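This account rests on a few compounds, and the source may have more. Where it says the series, first, only, none or still open, it means among the compounds named here.

The series shares a single core built around a morpholinylsulfonyl group, and the compounds differ in what is attached at the double-bonded nitrogen of that core. Compound 1 is `O=C1Nc2ccc(S(=O)(=O)N3CCOCC3)cc2/C1=N/NS(=O)(=O)c1ccccc1`. In a functional assay on HepG2 cells (Homo sapiens) for cytotoxicity, read by sulforhodamine B assay, with a stated time of 24 h (a lower number here means a stronger inhibitor, a higher number a weaker inhibitor), compound 1 gives 23900 nM. Compound 2 is `N=c1oc2ccccc2cc1C(=O)N/N=C1\C(=O)Nc2ccc(S(=O)(=O)N3CCOCC3)cc21`, and in this assay compound 2 gives 7820 nM. Compound 3 is `O=C1Nc2ccc(S(=O)(=O)N3CCOCC3)cc2/C1=N/c1ccc(/N=C2\C(=O)Nc3ccc(S(=O)(=O)N4CCOCC4)cc32)cc1`, and in this assay compound 3 gives 8840 nM. Of the three measured compounds, compound 1 therefore gives the highest number; the gap to compound 3 is the smaller one, that to compound 2 the larger, and both gaps lie beyond the scatter of repeated measurements.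

The next compound, compound 4, is `O=C1Nc2ccc(S(=O)(=O)N3CCOCC3)cc2/C1=N/c1ccc(Br)cc1`. It arises from compound 1 by one change: 4-bromophenyl in place of (phenylsulfonyl)amino on a double-bonded nitrogen. Within the data shown here, no step between measured compounds isolates this change, but the aryl imine in compound 3 accompanies a lower number than the sulfonylhydrazone of compound 1, which points toward a modest gain. The step of a 2.4-fold lower number from compound 1 to compound 4 (0.38 log units; beyond the scatter) is expected to be a moderate decrease, somewhat beyond the scatter. Compound 4 is estimated at 10000 nM, within a range from 4000 nM to 25000 nM.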

Compound 4, half-maximal inhibitory concentration: 11900 nM
Beside the measured number, compound 4's estimate is 1.2-fold (0.08 log units) below it, within the range that was stated.
By their numbers in this assay, from the lowest: compounds 2, 3, 4 and 1 (each within the scatter of the next, the first and the last beyond it).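

In this assay, among these compounds, exchanging (phenylsulfonyl)amino for 4-bromophenyl on a double-bonded nitrogen gives a 2.0-fold lower number from compound 1 to compound 4 (0.30 log units; within the scatter), the first step that isolates a single change at this position. The exchange removes the sulfonyl group along with the hydrogen-bond donor and acceptors counted on the leaving group, while one six-membered aromatic ring of carbon only is present on both sides, and the result stays within the scatter, so this assay does not separate the two groups at this position. No measured property of either group is available to account for this result.

On these data alone, it remains open whether the bromine of 4-bromophenyl has any bearing on the reading, or whether a plain phenyl, or a phenyl carrying an amine or a carboxylic acid in place of the bromine, would read alike on this nitrogen. As far as these compounds go, it is equally open whether the same exchange would give a similar step on a core with a piperidinylsulfonyl group in place of the morpholinylsulfonyl group.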